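Aryl swap on the triazole nitrogen in a spiro-oxindole series

This account rests on a few compounds, and the source may have more. Where it says the series, first, only, none or still open, it means among the compounds named here.

In a functional assay on MCF7 cells (Homo sapiens) for antiproliferative activity, read by MTT assay, with a stated time of 48 h (on this read-out lower numbers stand for stronger inhibition and higher numbers for weaker inhibition), compound 1 `N#CC1=C(N)Oc2c(c3nc4ccccc4nc3c3ccccc23)C12C(=O)N(Cc1cnnn1-c1ccc(Cl)cc1)c1ccccc12` gives only a limit, > 50000 nM. Compound 2 `COc1ccccc1-n1nncc1CN1C(=O)C2(C(C#N)=C(N)Oc3c2c2nc4ccccc4nc2c2ccccc32)c2ccccc21` likewise reaches only a limit in this assay, > 50000 nM. Going by the values given here, the single one-place step between measured compounds, a step that the two limits leave unreadable from compound 1 to compound 2, therefore has no readable size; both values sit at the limit of > 50000 nM in this assay, at which 3 of the 3 values shown sit. Compound 3 `CCOc1ccccc1-n1nncc1CN1C(=O)C2(C(C#N)=C(N)Oc3c(N)cc4nc5ccccc5nc4c32)c2ccccc21` also stands at a limit in this assay, > 50000 nM, so nothing more can be said of its standing than that it shares the same limit with the other two compounds.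

Compound 4 `N#CC1=C(N)Oc2c(N)cc3nc4ccccc4nc3c2C12C(=O)N(Cc1cnnn1-c1c(Cl)cc(Cl)cc1Cl)c1ccccc12` differs from compound 3 in one place: 2,4,6-trichlorophenyl in place of 2-ethoxyphenyl on an aromatic nitrogen. Among the compounds with values here, the only measured step at the same aromatic nitrogen is a step that the two limits leave unreadable from compound 1 to compound 2, and its size cannot be read, so no measured evidence bears on the direction or size of the change. With every value in the series at the same limit, the step from compound 3 to compound 4 is expected to be a step that the limit leaves unreadable from compound 3 to compound 4, that is, no readable movement. Compound 4 is expected to give about 70000 nM in this assay, within 20000 nM to 250000 nM, and most likely again only a limit rather than a number.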

Compound 4, half-maximal inhibitory concentration: 37800 nM
For compound 4 the middle estimate is 1.9-fold (0.27 log units) above the measured one; low and high end bracket the measured number.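

Going by these compounds alone, at this aromatic nitrogen, 2,4,6-trichlorophenyl in place of 2-ethoxyphenyl gives the only readable number so far in this assay, and the change is an at least 1.3-fold lower number from compound 3 to compound 4 (0.12 log units; that floor lies within the scatter). One end of that step is a limit, so only a floor for its size is known, and that floor does not by itself establish a real difference between the two aryl groups. The earlier step at the same nitrogen, between 4-chlorophenyl and 2-methoxyphenyl, still cannot be read, and no other number stands beside this one: the limit of > 50000 nM in this assay, at which 3 of the 4 values shown sit.

As far as these compounds go, it remains open whether the reading of compound 4 depends on all three chlorines or on only some of them, and how far the true step extends beyond its floor. Also open, from the compounds shown here alone, is what a plain phenyl, a pyridine ring or a 2,4,6-trifluorophenyl would give at this nitrogen on the core of compound 3, and whether 2,4,6-trichlorophenyl would give a number on the core of compound 1.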